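The compounds below may be only part of what the source reports. "The series", "measured", "known", "first", "only" and "open" are said of these compounds alone.

Measured so far:
- compound 1 `Nc1ccccc1NC(=O)/C=C/c1ccc(CSc2ccc(Cl)cc2)cc1`: 5.62%
- compound 2 `CCc1ccc(SCc2ccc(/C=C/C(=O)Nc3ccccc3N)cc2)cc1`: 3.29%
- compound 3 `Nc1ccccc1NC(=O)c1ccc(CSc2ccc(Br)cc2)cc1`: 9.96%

All three were tested in a functional assay on HCT-116 cells (Homo sapiens) for inhibition, read by CCK-8 assay, with a stated time of 72 h, tested at 2 uM (a higher number here means more inhibition of growth at the concentration tested, a lower number less inhibition of growth), and the values lie within the scatter of one another. Compound 2, at 3.29%, therefore cannot be separated from compound 1 or compound 3 on these numbers.

The next compound is compound 4 `Nc1ccccc1NC(=O)/C=C/c1ccc(CSc2cccc3ccccc23)cc1`, which is related to compound 2 by a single change: naphthalen-1-yl in place of 4-ethylphenyl on a sulfur. In words, naphthalen-1-yl stands in place of 4-ethylphenyl on a sulfur. Within the data shown here, only one measured step bears on this change, a number 2.3 percentage points lower from compound 1 to compound 2 (within the scatter), and it stays within the scatter. That step is only a partial guide, since it swaps chloro for ethyl on an aromatic carbon, while the new change replaces the whole group on the sulfur. Among the measured compounds shown here, no measurement yet shows what such a replacement does.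

For the measured compounds named here, with that single small step as the only guide, no shift beyond the scatter is expected, and the range is left wider on the upper side. The expected move is a number 3.7 percentage points higher from compound 2 to compound 4 (within the scatter), which would remain within the scatter. For compound 4 the estimated value is 7%, with an expected range from 1% to 22%.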

Compound 4, percent growth inhibition at one concentration: 11%
For compound 4 the middle estimate is 4 percentage points below the measured one; low and high end bracket the measured number.
By their numbers in this assay, from the lowest: compounds 2, 1, 3 and 4 (each within the scatter of the next).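

Among these compounds, the step from compound 2 is the first in this set that replaces the whole group on the sulfur rather than a single substituent on its ring: in this assay, naphthalen-1-yl in place of 4-ethylphenyl gives a number 7.7 percentage points higher from compound 2 to compound 4 (within the scatter), and naphthalen-1-yl in place of 4-chlorophenyl gives a number 5.4 percentage points higher from compound 1 to compound 4 (within the scatter). At this position, on a sulfur whose other neighbour is a saturated chain carbon, exchanging one six-membered aromatic ring of carbon for two therefore produces no difference that can be separated from the scatter in either comparison, so the larger replacement has so far proved as uninformative as the smaller swap of chloro for ethyl. No measured evidence bears on why these numbers fall as they do.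

On these data alone, it remains open whether a different kind of group on the sulfur, such as a carboxylic acid, an amine or a longer saturated chain in place of the aromatic group, would move the number beyond the scatter. As far as these compounds go, it is also open whether naphthalen-1-yl would behave in the same way on the core of compound 3.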